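Adding one carbon to the ester chain

The compounds below may be only part of what the source reports. "The series", "measured", "known", "first", "only" and "open" are said of these compounds alone.

Compound 1 `O=C1C2=C(CCCC2)C(=O)N1c1ccc(Cl)cc1F` gives 37.2 nM in a functional assay on the whole organism for inhibition, with Scenedesmus acutus as the target; a higher number here means a weaker inhibitor, a lower number a stronger inhibitor
Compound 2 `CCOC(=O)c1cc(N2C(=O)C3=C(CCCC3)C2=O)c(F)cc1Cl` gives 57.5 nM in this assay

Among the compounds with values here, with only two numbers so far, compound 2 stands within the scatter of compound 1. Compound 3 `CCCOC(=O)c1cc(N2C(=O)C3=C(CCCC3)C2=O)c(F)cc1Cl` differs from compound 2 by methyl in place of hydrogen on a saturated chain carbon, two bonds along the chain from an oxygen next to a carbonyl group and this turns ethoxy to propoxy. Within the data shown here, no measured pair alters the ester chain itself, so the evidence is indirect. Among the measured compounds shown here, the one step that bears on the change is a 1.5-fold higher number from compound 1 to compound 2 (0.19 log units; within the scatter) and it came from ethoxycarbonyl in place of hydrogen on an aromatic carbon. On the size of that step, no change beyond the scatter is expected in this assay and no firm direction can be given. The estimated step is a 1.0-fold higher number from compound 2 to compound 3 (0.02 log units; within the scatter) on this reasoning. For compound 3 the expected value is 60 nM with an estimated range from 25 nM to 140 nM as the likely span.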

Compound 3, half-maximal inhibitory concentration: 33.1 nM
The estimate for compound 3 lay 1.8-fold (0.26 log units) above the measured number, and the stated range covers the measured number.
By their numbers in this assay, from the lowest: compounds 3, 1 and 2 (each within the scatter of the next).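

Lengthening ethoxy to propoxy gives a 1.7-fold lower number from compound 2 to compound 3 (0.24 log units; within the scatter) in this assay, the first direct reading on the ester chain itself: one added methyl on this saturated chain carbon brings no change that can be told from the scatter. Measured against the core with hydrogen at that aromatic carbon, propoxycarbonyl gives a 1.1-fold lower number from compound 1 to compound 3 (0.05 log units; within the scatter), so this larger group also stays within the scatter, as ethoxycarbonyl did. No further measurement is available to explain these results.

On these data alone, whether a still longer chain, such as butoxy, or a branched one, such as isopropoxy, would also stay within the scatter remains open. So does how a carboxylic acid or an amide in place of the ester would read in this assay, since all the compounds shown with a group at that carbon are esters.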